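The source may report more compounds than this note shows. Statements on the series, on what has been measured and on what is new or still open speak of the compounds shown alone.

Measured compounds and their values:

compound 1 `O=c1ccn(CCN2CCCCC2)c(CO)c1O`: 2.25
compound 2 `Cn1cc(O)c(=O)cc1CN1CCCCC1`: 2.15
compound 3 `CCc1c(O)c(=O)ccn1CCCn1ccnc1`: 3.09

These three compounds were examined in a physicochemical assay for acid dissociation, using potentiometric titration. Among them compound 3 stands highest: its value lies above that of compound 1 by a margin beyond the scatter, and further still above that of compound 2, again beyond the scatter. Compound 1 and compound 2 sit close to each other, with nothing between them that rises above the usual scatter.

Compound 4 `CCc1c(O)c(=O)ccn1CCN(C)C` has not yet been measured. It differs from compound 3 in one place: dimethylamino in place of (1H-imidazol-1-yl)methyl on a saturated chain carbon, two bonds along the chain from an aromatic nitrogen. Compound 1 carries a saturated amine on a two-carbon chain from the same kind of ring nitrogen and gives 2.25 in this assay, and compound 4 now carries a saturated amine on such a chain as well. On that ground the value of compound 4 is expected to fall below that of compound 3, a step of a number 0.69 log units lower from compound 3 to compound 4 (beyond the scatter), which would lie beyond the scatter. The estimate for compound 4 in this assay is 2.4, with a range from 1.9 to 2.9.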

Compound 4, acid dissociation constant: 2.62
Estimate against measurement, compound 4: 0.22 log units below; the range from low to high includes it.
By their numbers in this assay, from the lowest: compounds 2 and 1 (each within the scatter of the next); then compound 4; then compound 3.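

Within this assay, the change from (1H-imidazol-1-yl)methyl to dimethylamino on a saturated chain carbon, two bonds along the chain from an aromatic nitrogen, gives a number 0.47 log units lower from compound 3 to compound 4 (beyond the scatter) as a modest step. For the compounds shown here, this is the first pair differing in one place, and it shows that the group at this chain position can move the read-out by more than the usual scatter. The change replaces a five-membered aromatic ring of six heavy atoms with an open group of three, and nothing available here accounts for the shift.

This single step cannot separate the loss of the ring from the change in group size. A primary amine, a morpholine ring or a carboxylic acid at the same place, or dimethylamino on a longer chain, would show how far the effect extends.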